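Anilino series: bromo to methoxy on the aryl ring

The compounds below may be only part of what the source reports. "The series", "measured", "known", "first", "only" and "open" are said of these compounds alone.

Compound 1 is `C=C1[C@@H](OC(C)=O)C[C@@H]2[C@](C)(CO[Si](C)(C)C(C)(C)C)[C@H](OC(C)=O)CC[C@@]2(C)[C@@H]1C[C@@H](Nc1ccc(Br)cc1)C1=CCOC1=O`. In a functional assay on KB cells (Homo sapiens) for cytotoxicity, read by sulforhodamine B assay (a lower number here means a stronger inhibitor, a higher number a weaker inhibitor), compound 1 gives 5230 nM, the lowest of the two numbers at hand. Compound 2, `C=C1[C@@H](C/C=C2/C(=O)OC[C@H]2OC(C)=O)[C@]2(C)CC[C@@H](OC(C)=O)[C@@](C)(CO[Si](C)(C)C(C)(C)C)[C@H]2C[C@@H]1O`, sits nearest: in this assay compound 2 gives 9790 nM, a gap to compound 1 that stays within the scatter, so no order between the two is claimed. Compound 3 is `C=C1[C@@H](OC(C)=O)C[C@@H]2[C@](C)(COC=O)[C@H](OC(C)=O)CC[C@@]2(C)[C@@H]1C[C@@H](Nc1ccc(C(=O)O)cc1)C1=CCOC1=O`; in this assay compound 3 reaches only the limit > 50000 nM, which is a limit of the assay and not a number. Among the measured compounds shown here, of the three values, then, one sits at the limit of > 50000 nM in this assay, at which 1 of the 3 values shown sits, and no single-change step between measured compounds exists in this set.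

Compound 4 is `C=C1[C@@H](OC(C)=O)C[C@@H]2[C@](C)(CO[Si](C)(C)C(C)(C)C)[C@H](OC(C)=O)CC[C@@]2(C)[C@@H]1C[C@@H](Nc1ccc(OC)cc1)C1=CCOC1=O`. It differs from compound 1 by methoxy in place of bromo on an aromatic carbon, on the aromatic carbon para to a large group. For the measured compounds named here, no measured step informs this change, and the set gives no evidence on what the methoxy or the bromo contributes. The step is therefore expected to be small, within the scatter or at most a modest rise, with no direction firmly supported. Compound 4 is estimated at 6500 nM in this assay, with a range from 2500 nM to 17000 nM. The expected step from compound 1 to compound 4 is a 1.2-fold higher number from compound 1 to compound 4 (0.09 log units; within the scatter).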

Compound 4, half-maximal inhibitory concentration: 5630 nM
Estimate against measurement, compound 4: 1.2-fold (0.06 log units) above; low and high end bracket the measured number.
By their numbers in this assay, from the lowest: compounds 1, 4 and 2 (each within the scatter of the next). At a limit, above all of these: compound 3.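

Working notes, anilino series. In this assay, among the compounds shown here, methoxy in place of bromo on an aromatic carbon, para to a large group, gives a 1.1-fold higher number from compound 1 to compound 4 (0.03 log units; within the scatter) and is the first single-change step available in this set. Bromo and methoxy can thus be exchanged at this carbon with no readable difference in this assay, even though the exchange brings in one hydrogen-bond acceptor and one more heavy atom. This single step supports no wider rule for the position, and nothing measured here bears on why the two groups read alike.

Still open, as far as these compounds go, is whether this flat reading extends to other groups at the same carbon, such as a dimethylamino group, a nitrile or a longer alkoxy chain, and whether any of them would move the value beyond the scatter. For compound 3, the value > 50000 nM is a limit of the assay and not a number, and that compound differs from compound 1 in more than one place, leaving the contribution of its carboxylic acid on the aryl ring unresolved.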